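A few compounds are considered here, and "the series" means these few. Any claim that something is new, unique, unknown or untested is made for them only; others in the source may bear on it.

Measured so far:
compound 1, `CCOC(=O)c1cnn(CC(O)CC)c1NC(=O)Nc1cccc2ccccc12`: 12 nM
compound 2, `CCOC(=O)c1cnn(CC(C)O)c1NC(=O)Nc1cccc(F)c1`: > 10 nM

In a functional assay on cells (Neutrophil, Homo sapiens) for inhibition, with a stated time of 10 min (on this read-out lower numbers stand for stronger inhibition and higher numbers for weaker inhibition), compound 1 gives 12 nM, the only full number shown. For compound 2 the result in this assay is a limit, > 10 nM, not a number. Compound 3, `CCOC(=O)c1cnn(CC(C)O)c1NC(=O)Nc1cccc2ccccc12`, is not yet measured; its difference from compound 1 is hydrogen in place of methyl on a saturated chain carbon, two bonds along the chain from an oxygen on a saturated carbon. Going by the values given here, no measured pair mirrors this change. The expected step is a 1.3-fold higher number from compound 1 to compound 3 (0.10 log units; within the scatter), nothing beyond the usual scatter. For compound 3 the estimate in this assay is 15 nM, range 5 nM to 45 nM.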

Compound 3, half-maximal inhibitory concentration: 9.8 nM
Estimate against measurement, compound 3: 1.5-fold (0.18 log units) above; the measured number falls inside the stated range.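

In this assay, the 2-hydroxybutyl of compound 1 and the 2-hydroxypropyl of compound 3 are not told apart: hydrogen in place of methyl at this carbon gives a 1.2-fold lower number from compound 1 to compound 3 (0.09 log units; within the scatter). Going by these compounds alone, this is the first reading of a change at this position, and it rests on a single pair. Compound 2 shares the 2-hydroxypropyl with compound 3, but its result is a limit and not a number, so no step to it can be read: the limit of > 10 nM in this assay, at which 1 of the 3 values shown sits.

From the compounds shown here alone, whether a longer chain at this carbon would stay within the scatter remains open. So does the effect of an amine or a carboxylic acid in place of the hydroxyl.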